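The source may report more compounds than this note shows. Statements on the series, on what has been measured and on what is new or still open speak of the compounds shown alone.

Of the compounds shown here, three built on one shared core have been measured: compound 1 `O=C(CSc1nnc(-c2ccncc2)o1)N/N=C/c1ccccc1`, compound 2 `O=C(CSc1nnc(-c2ccncc2)o1)N/N=C/c1ccc(Cl)cc1` and compound 3 `O=C(CSc1nnc(-c2ccncc2)o1)N/N=C/c1cc(Br)ccc1O`. In a functional assay on BGC-823 cells (Homo sapiens) for cytotoxicity, read by MTT assay, with a stated time of 48 h (a lower number here means a stronger inhibitor, a higher number a weaker inhibitor), compound 1 gives 22100 nM, compound 2 gives 20500 nM and compound 3 gives 9590 nM, the lowest of the three. The change a 1.1-fold lower number from compound 1 to compound 2 (0.03 log units; within the scatter) stays inside the scatter, whereas a 2.3-fold lower number from compound 1 to compound 3 (0.36 log units; beyond the scatter) and a 2.1-fold lower number from compound 2 to compound 3 (0.33 log units; beyond the scatter) both go beyond it, so compound 3 stands as the strongest of the set. Compound 4 `COc1cc(/C=N/NC(=O)CSc2nnc(-c3ccncc3)o2)ccc1O` differs from compound 3 by 4-hydroxy-3-methoxyphenyl in place of 5-bromo-2-hydroxyphenyl on a carbon with a double bond to nitrogen. Both earlier swaps of the aryl group on this carbon produced only modest shifts, so a modest shift is expected again, with the direction uncertain. Compound 4 is therefore estimated at 14000 nM, within 5000 nM to 40000 nM, which would mean an expected step of a 1.5-fold higher number from compound 3 to compound 4 (0.16 log units; within the scatter).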

Compound 4, half-maximal inhibitory concentration: 4320 nM
For compound 4 the middle estimate is 3.2-fold (0.51 log units) above the measured one; measured number below the stated range.
By their numbers in this assay, from the lowest: compound 4; then compound 3; then compounds 2 and 1 (each within the scatter of the next).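

In this assay, the aryl group on the carbon with a double bond to nitrogen proves able to move the number further than before: 4-hydroxy-3-methoxyphenyl gives a 2.2-fold lower number from compound 3 to compound 4 (0.35 log units; beyond the scatter), a 4.7-fold lower number from compound 2 to compound 4 (0.68 log units; beyond the scatter) and a 5.1-fold lower number from compound 1 to compound 4 (0.71 log units; beyond the scatter), making compound 4 the strongest of the set. Bromine is therefore not needed for a lower number here, and both aryl groups carrying a hydroxy group lie below phenyl and 4-chlorophenyl, with no compound shown going against this. No evidence at hand bears on this result.

Whether the hydroxy or the methoxy group accounts for the gain remains open, since the compounds shown do not separate the two. As far as these compounds go, it is also open how an amine or a carboxylic acid on this aryl ring would compare.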